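A few compounds are considered here, and "the series" means these few. Any claim that something is new, unique, unknown or untested is made for them only; others in the source may bear on it.

Of the compounds shown here, two have been tested in a functional assay on KM12 cells (Homo sapiens) for inhibition, read by sulforhodamine B assay, with a stated time of 48 h; a higher number here means a weaker inhibitor of growth, a lower number a stronger inhibitor of growth. Compound 1 `N#C/C(=C\N1CCN(C(=O)c2ccco2)C1=S)C(N)=O` gives 7500 nM in this assay. Compound 2 `O=CN1CCN(c2ccc(Cl)cc2)C1=S` gives 12700 nM in this assay, which is the higher of the two numbers; the gap to compound 1 lies within the scatter, so the two results cannot be separated.

Compound 3 `O=CN1CCN(c2ccc(Cl)c(Cl)c2)C1=S` has not yet been measured. It differs from compound 2 in one place: chloro in place of hydrogen on an aromatic carbon. Going by the values given here, no measured pair isolates this change, so its effect on growth inhibition in this assay is unknown from the present data. With no comparison to lean on, the safest expectation is a small step, and the step expected here is a 1.4-fold lower number from compound 2 to compound 3 (0.15 log units; within the scatter), in the direction of a slightly lower number and likely within the scatter. On that basis compound 3 is estimated to give about 9000 nM in this assay, with an expected range from 3500 nM to 25000 nM.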

Compound 3, concentration for 50% growth inhibition: 15700 nM
Compound 3: middle estimate off by 1.7-fold (0.24 log units), on the low side; the measured number falls inside the stated range.
By their numbers in this assay, from the lowest: compounds 1, 2 and 3 (each within the scatter of the next, the first and the last beyond it).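

Going by these compounds alone, this pair gives the first direct reading of chloro in place of hydrogen on an aromatic carbon, here on a six-membered aromatic ring of carbon only, ortho to a chloro group and meta to a group of 8 heavy atoms. In this assay the step is a 1.2-fold higher number from compound 2 to compound 3 (0.09 log units; within the scatter), so at this position a second chloro group on the ring cannot be told apart from hydrogen, although this single pair says nothing about any other position or any other core. No measurement at hand offers an explanation for this result.

The compounds shown leave open whether this position tolerates other kinds of group just as evenly, such as a methoxy group, an amine or a carboxylic acid, any of which could give a step that lies beyond the scatter. Within the data shown here, they also leave open whether a chloro group elsewhere on the ring would behave in the same way, and what the chloro group already on the ring contributes, since no compound with hydrogen in its place appears here.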